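Methyl branch on the acid side chain: compound 4

The compounds below may be only part of what the source reports. "The series", "measured", "known", "first", "only" and "open" are said of these compounds alone.

Compound 1 `COC(=O)CNc1cc(NS(=O)(=O)/C=C/c2c(OC)cc(OC)cc2OC)ccc1OC` carries methoxycarbonyl on the chain that sits on the ring nitrogen. In a functional assay on K562 cells (Homo sapiens) for cytotoxicity, read by trypan blue exclusion, with a stated time of 96 h (a lower number here means a stronger inhibitor, a higher number a weaker inhibitor), compound 1 gives 350 nM. Compound 2 `COC(=O)C(C)Nc1cc(NS(=O)(=O)/C=C/c2c(OC)cc(OC)cc2OC)ccc1OC` differs from it by methyl in place of hydrogen on a saturated chain carbon bound to a carbonyl carbon and a nitrogen on an aromatic ring; in this assay compound 2 gives 300 nM, and a 1.2-fold lower number from compound 1 to compound 2 (0.07 log units; within the scatter). Compound 3 `COc1cc(OC)c(/C=C/S(=O)(=O)Nc2ccc(OC)c(NCC(=O)O)c2)c(OC)c1` carries carboxy where compound 1 carries methoxycarbonyl; in this assay compound 3 gives 20 nM, so that an 18-fold lower number from compound 1 to compound 3 (1.24 log units; beyond the scatter), and against compound 2 a 15-fold lower number from compound 2 to compound 3 (1.18 log units; beyond the scatter). Compound 3 thus has the lowest number of the three, with both of its steps beyond the scatter.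

Compound 4 `COc1cc(OC)c(/C=C/S(=O)(=O)Nc2ccc(OC)c(NC(C)C(=O)O)c2)c(OC)c1` has not been measured. It stands to compound 3 as compound 2 stands to compound 1, the change being (methyl in place of hydrogen on a saturated chain carbon bound to a carbonyl carbon and a nitrogen on an aromatic ring). The two cores on which this change is made differ by hydrogen in place of methyl on an oxygen next to a carbonyl group. The place of the change is described in the same words for both pairs, so it is the same change, carried from the core of compound 1 onto the core of compound 3. The change has been measured only once, on compounds 1 and 2; whether it reads the same on the acid core rests on that single pair alone.

Among the compounds with values here, for compound 4 the expected step is a 1.1-fold lower number from compound 3 to compound 4 (0.05 log units; within the scatter) because a 1.2-fold lower number from compound 1 to compound 2 (0.07 log units; within the scatter), the only measured instance of this change, lies within the scatter. Compound 4 is expected to give 18 nM in this assay, with a range from 8 nM to 40 nM.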

Compound 4, half-maximal inhibitory concentration in the K562 assay: 8 nM
Compound 4: the middle estimate sits 2.3-fold (0.35 log units) above what was measured; the range from low to high includes it.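

On the acid core, in the K562 assay, methyl in place of hydrogen on the saturated chain carbon gives a 2.5-fold lower number from compound 3 to compound 4 (0.40 log units; beyond the scatter), and the same change on the other core gives a 1.2-fold lower number from compound 1 to compound 2 (0.07 log units; within the scatter); the two steps agree: the same change on two cores in the K562 assay, a 1.2-fold lower number (0.07 log units; within the scatter) from compound 1 to compound 2 and a 2.5-fold lower number (0.40 log units; beyond the scatter) from compound 3 to compound 4, 2.1-fold (0.33 log units) apart, within the scatter of two such steps Hydrogen in place of methyl on an oxygen next to a carbonyl group also carries across the methyl branch, giving a 38-fold lower number from compound 2 to compound 4 (1.57 log units; beyond the scatter), while the two changes taken together give a 44-fold lower number from compound 1 to compound 4 (1.64 log units; beyond the scatter): the same change on two cores in the K562 assay, an 18-fold lower number (1.24 log units; beyond the scatter) from compound 1 to compound 3 and a 38-fold lower number (1.57 log units; beyond the scatter) from compound 2 to compound 4, 2.1-fold (0.33 log units) apart, within the scatter of two such steps Within these four compounds, each change therefore reads alike on both cores within the scatter, but each comparison rests on a single pair per core, and this agreement does not show that the steps are identical or that they would hold on any other core. In a physicochemical assay for solubility (a lower number here means a less soluble compound, a higher number a more soluble compound), compound 3 gives 10000 ug/mL and compound 4 gives 10000 ug/mL, so that there is no change at the digits printed from compound 3 to compound 4 (within the scatter).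

The compounds shown leave open whether ethyl or a longer chain in place of methyl on the same saturated chain carbon would continue the step seen with methyl in the K562 assay. They also leave open whether an amide in place of the carboxylic acid would keep numbers close to those of compound 3 and compound 4.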